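Cytotoxicity at the Assay Limit: Three Compounds and a Fourth

The compounds below may be only part of what the source reports. "The series", "measured", "known", "first", "only" and "open" are said of these compounds alone.

Compound 1 `Cc1ccc(-c2nnc(N3CCN(C(=O)CN4CCN(c5ccc([N+](=O)[O-])cc5)CC4)CC3)nc2-c2ccc(C)cc2)cc1` gives > 844000 nM, a limit of the assay.
Compound 2 `COc1ccc(-c2nnc(N3CCN(C(=O)CN4CCN(c5cccc(OC)c5)CC4)CC3)nc2-c2ccc(OC)cc2)cc1` gives > 821000 nM, again a limit.
Compound 3 `O=C(CN1CCN(c2ccccc2)CC1)N1CCN(c2nnc(-c3ccc(Cl)cc3)c(-c3ccc(Cl)cc3)n2)CC1` gives > 850000 nM, also a limit.

All three measured compounds were tested in an ADME assay on NIH3T3 cells (Mus musculus) for cytotoxicity, read by MTT assay, with a stated time of 24 h (a lower number here means a stronger inhibitor, a higher number a weaker inhibitor), and none of them reached a measurable number. The readings are limits of the assay rather than values: compound 1 sits at the limit (the limit of > 844000 nM in this assay, at which 1 of the 3 values shown sits), compound 2 sits at the limit (the limit of > 821000 nM in this assay, at which 1 of the 3 values shown sits), and compound 3 sits at the limit (the limit of > 850000 nM in this assay, at which 1 of the 3 values shown sits). Compound 3 therefore stands where the other two stand, with no number that could be ranked against theirs.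

Compound 4 `O=C(CN1CCN(c2ccc(Cl)cc2)CC1)N1CCN(c2nnc(-c3ccc(Cl)cc3)c(-c3ccc(Cl)cc3)n2)CC1` is not yet measured. It differs from compound 3 by chloro in place of hydrogen on an aromatic carbon, so that a phenyl becomes a 4-chlorophenyl. Among the compounds with values here, no step between measured compounds is available to size this change. Given that compound 3 gives > 850000 nM only as a limit, the expected step of a number no higher from compound 3 to compound 4 (the limit leaves the size open) is no change beyond the scatter, and compound 4 is expected to remain at the limit, estimated at 850000 nM with a range from 300000 nM to 2000000 nM.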

Compound 4, half-maximal inhibitory concentration: > 803000 nM
Compound 4 ended at the assay's limit; the forecaster's own chance of this, stated with the estimate: 90%; the middle value does not contradict the limit.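

Compound 3 and compound 4 both stop at a limit in this assay, so the step from phenyl to 4-chlorophenyl cannot be read and no size can be given to it. The compounds shown leave open whether any of them would reach a measurable number in this assay, and how far their true values lie apart.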